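The source may report more compounds than this note shows. Statements on the series, on what has been measured and on what is new or still open speak of the compounds shown alone.

Measured so far:
- compound 1 `CCNCCCNCCCN`: > 100000 nM
- compound 2 `CCCNCCCNCCCN`: 100000 nM
- compound 3 `CNCCCCNCCCNC`: 1700 nM

All three values come from a functional assay on L1210 cells (Mus musculus) for inhibition, with a stated time of 96 h; a higher number here means a weaker inhibitor, a lower number a stronger inhibitor. Compound 1 stands at the limit of > 100000 nM in this assay, at which 1 of the 3 values shown sits. That value is a limit and not a number, so compound 1 can only be placed at the weak end of what was measured.

The next compound to consider is compound 4 `CCNCCCCNCCCNCC`. Relative to compound 1, (ethylamino)methyl takes the place of amino on a saturated chain carbon, three bonds along the chain from an amine nitrogen ((ethylamino)methyl in place of amino on a saturated chain carbon, three bonds along the chain from an amine nitrogen).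

Going by the values given here, only one measured step touches compound 1, a number no higher from compound 1 to compound 2 (the limit leaves the size open), and its size stays open. It therefore gives no measure of how far compound 4 might move. The better guide is compound 3, which, like compound 4, has no plain amino end. Compound 3 gives 1700 nM, a much lower number than the value of compound 2 at 100000 nM.

A clear move towards stronger inhibition in this assay is therefore expected, well beyond the scatter, and the estimated change is an at least 50-fold lower number from compound 1 to compound 4 (1.69 log units; beyond the scatter). Among the compounds with values here, with only one close comparison, the expectation stays broad. For compound 4 the estimated value is 2000 nM, with an expected range of 300 nM to 15000 nM.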

Compound 4, half-maximal inhibitory concentration: 700 nM
Estimate against measurement, compound 4: 2.9-fold (0.46 log units) above; low and high end bracket the measured number.
By their numbers in this assay, from the lowest: compound 4; then compound 3; then compound 2.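

In this assay, putting (ethylamino)methyl in place of amino on a saturated chain carbon, three bonds along the chain from an amine nitrogen, gives an at least 140-fold lower number from compound 1 to compound 4 (2.15 log units; beyond the scatter). Going by these compounds alone, the value of compound 1 is a limit and not a number, so this size is a floor and the real step could be larger: the limit of > 100000 nM in this assay, at which 1 of the 4 values shown sits. The only earlier step from compound 1 cannot be read for size, so this is the first sign that a change at this place can move the number by a large, measurable margin, with a group of 4 heavy atoms replacing one of 1 heavy atom.

The swap changes several things at once, adding both carbons and an amine nitrogen, so these compounds do not show which of them accounts for the lower number. As far as these compounds go, it also remains open whether the amine nitrogen in the new group is needed, as a plain butyl chain at the same place would test, and whether a longer chain than ethyl on that nitrogen would lower the number further or raise it.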